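A few compounds are considered here, and "the series" means these few. Any claim that something is new, unique, unknown or untested is made for them only; others in the source may bear on it.

Notes on the series in a functional assay on cells (Macrophage, Homo sapiens) for cytotoxicity, read by MTT assay, with a stated time of 24 h; a higher number here means a weaker inhibitor, a lower number a stronger inhibitor: compound 1 (`Cc1ccc(N2CCN(CC(O)COc3cc(=O)oc4ccccc34)CC2)c(C)c1`) gives 127000 nM, compound 2 (`COc1cccc(N2CCN(CC(O)COc3cc(=O)oc4ccccc34)CC2)c1`) gives 178000 nM and compound 3 (`COc1ccccc1N1CCN(C(=O)COc2cc(=O)oc3ccccc23)CC1`) gives 164000 nM. Compound 3 stands within the scatter of both compound 1 and compound 2, so the three numbers form one group without an order.

Compound 4 (`COc1cccc(N2CCN(C(=O)COc3cc(=O)oc4ccccc34)CC2)c1`) has 3-methoxyphenyl in place of the 2-methoxyphenyl of compound 3 on an amine nitrogen in a ring: 3-methoxyphenyl in place of 2-methoxyphenyl on an amine nitrogen in a ring. For the measured compounds named here, no measured pair compares these two groups directly. The nearest evidence is a 1.4-fold higher number from compound 1 to compound 2 (0.15 log units; within the scatter), where 3-methoxyphenyl replaced 2,4-dimethylphenyl at that same nitrogen, and this step stays within the scatter.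

No step beyond the scatter is therefore expected in this assay, in either direction. The estimated step is a 1.0-fold higher number from compound 3 to compound 4 (0.00 log units; within the scatter). The expected value for compound 4 is 165000 nM, with an estimated range of 95000 nM to 285000 nM.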

Compound 4, half-maximal inhibitory concentration: 141000 nM
Compound 4: middle estimate off by 1.2-fold (0.07 log units), on the high side, within the range that was stated.
By their numbers in this assay, from the lowest: compounds 1, 4, 3 and 2 (each within the scatter of the next).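

In this assay, for the compounds shown here, the first direct comparison of 3-methoxyphenyl with 2-methoxyphenyl on the amine nitrogen in a ring gives a 1.2-fold lower number from compound 3 to compound 4 (0.07 log units; within the scatter) and so replaces the indirect reading from the other substituted phenyl groups with a matched pair. The two groups have the same atoms and differ only in how they are joined, and in this matched pair that difference does not separate the numbers, so compound 4 joins compounds 1, 2 and 3 in one group without an order. Nothing available accounts for this lack of separation, and no measurement beyond the assay values bears on it.

The compounds shown leave open whether a phenyl ring carrying a carboxylic acid or an amine in place of methoxy would stay in this group. They also leave open whether a longer chain between the ring nitrogen and the shared core would do so.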